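A few compounds are considered here, and "the series" means these few. Any claim that something is new, unique, unknown or untested is made for them only; others in the source may bear on it.

Of the compounds shown here, three have so far been measured in a functional assay on WiDr cells (Homo sapiens) for antiproliferative activity, read by sulforhodamine B assay, with a stated time of 48 h; on this read-out lower numbers stand for stronger inhibition of growth and higher numbers for weaker inhibition of growth. Compound 1 `CC(C)C/C=C/C(=O)CC(O)CC(C)C` gives 21000 nM. Compound 2 `O=C(/C=C/c1ccccc1)CC(O)c1ccccc1` gives 14000 nM in this assay. Compound 3 `CC(C)CC(O)CC(=O)/C=C\c1ccccc1` gives 16000 nM in this assay. Among these three numbers compound 3 holds the second highest; its nearest neighbour is compound 2, whose number lies within the usual scatter of it, and its furthest is compound 1, whose number also lies within the scatter. The three values thus cannot be told apart with confidence, and no ordering among them is claimed.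

Compound 4 `Cc1ccc(/C=C\C(=O)CC(O)CC(C)C)cc1` has not yet been measured. It differs from compound 3 in one place: methyl in place of hydrogen on an aromatic carbon. Going by the values given here, no measured pair shows what such a change does, so no direction can be read from the data. The step from compound 3 to compound 4 in this assay is expected to be a 1.1-fold lower number from compound 3 to compound 4 (0.03 log units; within the scatter), a change not expected to go beyond the scatter. On this basis compound 4 is estimated at 15000 nM in this assay, with a range from 6000 nM to 40000 nM.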

Compound 4, concentration for 50% growth inhibition: 15000 nM
For compound 4 middle estimate and measured number coincide at the digits printed, within the range that was stated.
By their numbers in this assay, from the lowest: compounds 2, 4, 3 and 1 (each within the scatter of the next).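

In this assay, methyl in place of hydrogen on an aromatic carbon, para to a large group, gives a 1.1-fold lower number from compound 3 to compound 4 (0.03 log units; within the scatter). Going by these compounds alone, this is the first measured pair that differs in only one place, and it shows that adding this single carbon at this position leaves compound 3 and compound 4 indistinguishable in this read-out. No separate measurement is available here that could explain this result.

The compounds shown leave open whether a different group at this same position, such as an amine, a carboxylic acid or a longer chain, would move the number beyond the scatter. They also leave open whether methyl on another carbon of the ring would behave as it does here.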